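From Methyl to Acetyl: What Compound 4 Should Give

The source may hold more compounds than are shown below. What is called first, only, known or untested is meant among the compounds shown, and "the series" means these compounds.

Among the three measured compounds, compound 3, with the structure `Cc1cccc(N/N=C2\CCC(C)n3c2ncc(C(=O)O)c3=O)c1`, is the only one that yields a number in a functional assay on the whole organism for inhibition, with Rattus norvegicus as the target; on this read-out higher numbers stand for an effect only at larger amounts of compound and lower numbers for an effect already at smaller amounts: compound 3 gives 72.5 umol/kg. Compound 1, `CC1CC/C(=N\Nc2cccc(Cl)c2)c2ncc(C(=O)O)c(=O)n21`, sits at a limit of this assay rather than at a number, namely > 100 umol/kg. Compound 2, `CCOc1cccc(N/N=C2\CCC(C)n3c2ncc(C(=O)O)c3=O)c1`, likewise sits at a limit of this assay, > 1000 umol/kg. The change from chloro to methyl gives an at least 1.3-fold lower number from compound 1 to compound 3 (0.13 log units; that floor lies within the scatter), a floor that says little. The change from ethoxy to methyl gives an at least 13-fold lower number from compound 2 to compound 3 (1.13 log units; beyond the scatter), and because of the limit of > 1000 umol/kg in this assay, at which 1 of the 3 values shown sits, only its floor is known. The step from compound 1 to compound 2 is a step that the two limits leave unreadable from compound 1 to compound 2.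

Compound 4, `CC(=O)c1cccc(N/N=C2\CCC(C)n3c2ncc(C(=O)O)c3=O)c1`, differs from compound 3 by acetyl in place of methyl on an aromatic carbon. The comparison that bears most on it runs from compound 2 to compound 3, where removing the ethoxy in favour of methyl lowered the dose strongly; the acetyl now entering brings one hydrogen-bond acceptor back onto the same ring position, as the counted change shows. The dose for compound 4 is therefore expected to rise again, by about a 4.1-fold higher number from compound 3 to compound 4 (0.62 log units; beyond the scatter), with an estimate of 300 umol/kg for compound 4 and a range from 70 umol/kg to 1500 umol/kg, with a real chance that only a limit is reported.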

Compound 4, dose for 50% inhibition: > 1000 umol/kg
Compound 4: a limit, no number; the forecaster's own chance of this, stated with the estimate: 40%; middle value at least 3.3-fold (0.52 log units) away from the limit.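

Acetyl in place of methyl on this aromatic carbon, meta to a large group, gives an at least 13-fold higher number from compound 3 to compound 4 (1.13 log units; beyond the scatter) in this assay, which shows that the number seen with methyl does not survive this change at this position. Compound 4 gives no number but a limit, > 1000 umol/kg, and only a floor can be stated for the step because of where the read-out ends: the limit of > 1000 umol/kg in this assay, at which 2 of the 4 values shown sit. Methyl in compound 3 now stands as the only group of the four with a number, while the oxygen-bearing ethoxy of compound 2 and acetyl of compound 4 end at the same limit; compound 1 goes against any simple split by oxygen, since its chloro also gives only a limit.

The steps from compound 1 and from compound 2 to compound 4 cannot be read, so the order among these three compounds stays open. Also open, from the compounds shown here alone, is whether an ethyl group, a fluoro group, an amine or a longer chain such as propyl on this aromatic carbon would keep a number in this assay or end at a limit as well.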